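Halobenzyl variation in a thio-sugar adenine series

The compounds below may be only part of what the source reports. "The series", "measured", "known", "first", "only" and "open" are said of these compounds alone.

Measured compounds:
- compound 1 `O[C@@H]1[C@H](O)CS[C@H]1Cn1cnc2c(NCc3cccc(Br)c3)ncnc21`: in an assay on CHO cells for displacement of a labelled ligand from adenosine receptor A3 (Homo sapiens), with a stated time of 60 min, tested at 10 uM (on this read-out lower numbers stand for less inhibition and higher numbers for more inhibition at the one concentration tested (going by the name of the read-out)), compound 1 gives 6.1%
- compound 2 `O[C@@H]1[C@H](O)CS[C@H]1Cn1cnc2c(NCc3cccc(Cl)c3)ncnc21`: in this assay compound 2 gives 8.9%
- compound 3 `O[C@@H]1[C@H](O)CS[C@H]1Cn1cnc2c(NCc3cccc(I)c3)nc(Cl)nc21`: in this assay compound 3 gives 10%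

All three numbers are low and sit close together. Compound 3 holds the highest of the three, yet its gap to compound 2 and its gap to compound 1 both fall within the usual scatter, so no ordering among them can be read off. Among the measured compounds shown here, the one single-point step measured so far, a number 2.8 percentage points higher from compound 1 to compound 2 (within the scatter), is a halogen swap on the aromatic carbon of the benzyl group and stays within the scatter.

Compound 4 `O[C@@H]1[C@H](O)CS[C@H]1Cn1cnc2c(NCc3cccc(F)c3)nc(Cl)nc21` is not yet measured. It differs from compound 3 by fluoro in place of iodo on an aromatic carbon. For the measured compounds named here, the step from compound 1 to compound 2 is the only comparison that bears on a halogen-for-halogen exchange at this position, and it produced no change beyond the scatter. On that basis, in this assay compound 4 is expected to stay near compound 3, with the expected step of a number 2 percentage points lower from compound 3 to compound 4 (within the scatter) lying within the scatter. The estimate for compound 4 is therefore 8%, with a range from 0% to 18%.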

Compound 4, a percentage reported as inhibition, at one concentration (the size of the read-out at that concentration, not a potency): 17.6%
For compound 4 the middle estimate is 9.6 percentage points below the measured one; measured number inside the range.
By their numbers in this assay, from the lowest: compounds 1, 2, 3 and 4 (each within the scatter of the next, the first and the last beyond it).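

Fluoro in place of iodo is a second halogen exchange at this aromatic carbon, and in this assay the step is a rise of a number 7.6 percentage points higher from compound 3 to compound 4 (within the scatter) that, like the earlier chloro-for-bromo exchange, stays within the scatter. The earlier pair covered only bromo and chloro on a core without the added chloro, whereas this pair carries the exchange from iodo to fluoro on the chloro-bearing core, and the result is the same: no change that can be told from the scatter. Nothing available bears on why the number moves as it does in this pair.

On these data alone, whether any group at this place can move the number beyond the scatter stays open, since only halogens have been compared here, and an amine, a carboxylic acid or a longer chain in place of the halogen on the benzyl group could answer that. No pair shown differs only in the chloro on the core, so the part that chloro plays in this read-out cannot be judged from these compounds.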